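The source may hold more compounds than are shown below. What is called first, only, known or untested is meant among the compounds shown, and "the series" means these compounds.

Notes on the series. In an ADME assay on HepG2 cells (Homo sapiens) for cytotoxicity (a lower number here means that less compound is tolerated, a higher number that more compound is tolerated), compound 1 `CSc1cccc(N2C(=O)CN(c3ccc(C(F)(F)F)cc3)CC2C(=O)NC2CCCC2)c1` gives 10000 nM, and compound 2 `CSc1cncc(N2C(=O)CN(c3cccc(C(F)(F)F)c3)CC2C(=O)NC2CCCC2)c1` gives 26000 nM.

Compound 3 `O=C(NCC1CC1)C1CN(c2ccccc2)CC(=O)N1c1ccc2ccsc2c1` stands at > 50000 nM, which is a limit of the assay and not a number. Among the compounds with values here, the series so far holds (the limit of > 50000 nM in this assay, at which 1 of the 3 values shown sits).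

The next compound, compound 4 `N#Cc1cccc(NC(=O)C2CN(c3ccccc3)CC(=O)N2c2ccc3ccsc3c2)c1`, has 3-cyanophenyl in place of cyclopropylmethyl on an amide-type nitrogen of compound 3. The counted difference is 3-cyanophenyl in place of cyclopropylmethyl on an amide-type nitrogen.

Within the data shown here, no measured pair differs in one place, so this change has no direct precedent in this assay, and the expectation rests on the values alone. Those values show that members of the series can give numbers inside the measurable range, with compound 1 at 10000 nM and compound 2 at 26000 nM. A modest move towards a lower tolerated concentration is expected, and a reading that stays at the limit would not be a surprise. The estimated size of the change is an at least 1.7-fold lower number from compound 3 to compound 4 (0.25 log units; that floor lies within the scatter), and it remains uncertain since the starting point is only a limit.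

For compound 4 the expected value is 28000 nM, with an estimated range from 12000 nM to 50000 nM.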

Compound 4, half-maximal cytotoxic concentration: > 50000 nM
Compound 4 was reported as a limit (the forecaster's own chance of this, stated with the estimate: 35%); middle value at least 1.7-fold (0.25 log units) from the limit.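

Compound 3 and compound 4 both stand at a limit of this assay and not at a number, so no step can be read between them: the limit of > 50000 nM in this assay, at which 2 of the 4 values shown sit.

The compounds shown leave open how far 3-cyanophenyl in place of cyclopropylmethyl on an amide-type nitrogen shifts the tolerated concentration, if it shifts it at all.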